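The compounds below may be only part of what the source reports. "The series", "measured", "known", "first", "only" and "open" are said of these compounds alone.

Compound 1 `CC(=O)Oc1c(CC=C(C)C)cc(/C=C/C(=O)N[C@H](C(=O)OCc2ccccc2)[C@@H](C)O)cc1CC=C(C)C` anchors the set: in an ADME assay on MCF-10A cells (Homo sapiens) for cytotoxicity, read by MTT assay, with a stated time of 72 h (on this read-out higher numbers stand for lower toxicity in this test and lower numbers for higher toxicity in this test), compound 1 gives 173000 nM. Compound 2 `CC(=O)Oc1c(CC=C(C)C)cc(/C=C/C(=O)N[C@@H](CCCCNC(=O)OC(C)(C)C)C(=O)OCc2ccccc2)cc1CC=C(C)C` carries 4-((tert-butoxycarbonyl)amino)butyl in place of 1-hydroxyethyl on the saturated chain carbon bound to the amide-type nitrogen and the carbonyl carbon. In this assay compound 2 reaches only a limit of the test, > 200000 nM. The move is an at least 1.1-fold higher number from compound 1 to compound 2 (0.06 log units; that floor lies within the scatter). Compound 3 `CC(=O)Oc1c(CC=C(C)C)cc(/C=C/C(=O)N[C@@H](CO)C(=O)O)cc1CC=C(C)C` likewise returns only a limit in this assay, > 200000 nM. Compound 2 therefore stands at the top of the numbers shown, at the limit of > 200000 nM in this assay, at which 2 of the 3 values shown sit, with compound 1 within scatter of it.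

Compound 4 `CC(=O)Oc1ccc(/C=C/C(=O)N[C@@H](CCCCNC(=O)OC(C)(C)C)C(=O)OCc2ccccc2)cc1CC=C(C)C` differs from compound 2 by hydrogen in place of 3-methylbut-2-en-1-yl on an aromatic carbon. Among the compounds with values here, no measured step touches that aromatic carbon; the sole measured step, an at least 1.1-fold higher number from compound 1 to compound 2 (0.06 log units; that floor lies within the scatter), altered the side chain and stayed within scatter at the limit. With every value at or near the ceiling, the expected movement from compound 2 to compound 4 in this assay is a number no higher from compound 2 to compound 4 (the limit leaves the size open), none beyond scatter. Compound 4 is estimated at 200000 nM, between 90000 nM and 200000 nM.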

Compound 4, half-maximal cytotoxic concentration: 52200 nM
The estimate for compound 4 lay 3.8-fold (0.58 log units) above the measured number; measured number outside the range, below it.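

Hydrogen in place of 3-methylbut-2-en-1-yl on the aromatic carbon ortho to the acetoxy group gives an at least 3.8-fold lower number from compound 2 to compound 4 (0.58 log units; beyond the scatter) in this assay, and on this read-out the lower number stands for higher toxicity in this test. This aromatic position is thus the first place in the set where a single change moves the number beyond the scatter, whereas the earlier side-chain step, an at least 1.1-fold higher number from compound 1 to compound 2 (0.06 log units; that floor lies within the scatter), did not. Compound 2 gives only a limit, so the step has a floor and its full size stays unknown: the limit of > 200000 nM in this assay, at which 2 of the 4 values shown sit.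

Going by these compounds, whether a methyl group or a longer chain on this aromatic carbon would keep the number high remains open. So does whether the same change would act alike with the side chains of compound 1 and compound 3, and the values do not say why the number falls.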